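A few compounds are considered here, and "the series" means these few. Any claim that something is new, unique, unknown or untested is made for them only; others in the source may bear on it.

Measured in an ADME assay on S9 fraction from liver (Rattus norvegicus) for metabolic stability, read by LC-MS, using NADPH, with a stated time of 30 min; a higher number here means that more of the compound is left, a lower number that less of the compound is left:
compound 1 `CCCCCCCCc1ccc(OCC(=O)Cn2nnc(SC)n2)cc1`: < 5% (a limit of the assay, not a number)
compound 2 `CCCCCCCCc1ccc(OCC(=O)Cn2nnc(-c3cccc(C(=O)OC)c3)n2)cc1`: 19%
compound 3 `CCCCCCCCc1ccc(OCC(=O)Cn2nnc(-c3ccc(S(=O)(=O)N(C)C)cc3)n2)cc1`: 65%

Compound 3 holds the highest number in this small set, and its nearest neighbour is compound 2, with a number 46 percentage points higher from compound 2 to compound 3 (beyond the scatter).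

Compound 4 `CCCCCCCCc1ccc(OCC(=O)Cn2nnc(-c3cccc(S(=O)(=O)N(C)C)c3)n2)cc1` has the same atoms as compound 3, joined differently: 3-(dimethylsulfamoyl)phenyl stands in place of 4-(dimethylsulfamoyl)phenyl on an aromatic carbon (3-(dimethylsulfamoyl)phenyl in place of 4-(dimethylsulfamoyl)phenyl on an aromatic carbon). Within the data shown here, no measured step isolates this change.

The closest evidence is the step that gives a number 46 percentage points higher from compound 2 to compound 3 (beyond the scatter), though it alters the group and its ring numbering together. Compound 4 keeps the dimethylsulfamoyl group of compound 3, while its ring numbering matches the 3-(methoxycarbonyl)phenyl of compound 2. It may therefore fall between those two compounds. The steps of a number at least 14 percentage points higher from compound 1 to compound 2 (beyond the scatter) and a number at least 60 percentage points higher from compound 1 to compound 3 (beyond the scatter) bear on it less, as they start from methylsulfanyl and from a limit.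

A fall in this assay of modest to large size is expected, smaller than the full gap between compound 2 and compound 3. The estimated change is a number 20 percentage points lower from compound 3 to compound 4 (beyond the scatter). Compound 4 is expected to give 45%, with an estimated range from 22% to 70%.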

Compound 4, percent of the compound remaining: 9%
Beside the measured number, compound 4's estimate is 36 percentage points above it; measured number outside the range, below it.
By their numbers in this assay, from the lowest: compounds 4 and 2 (each within the scatter of the next); then compound 3. At a limit, below all of these: compound 1.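

In this assay, 3-(dimethylsulfamoyl)phenyl in place of 4-(dimethylsulfamoyl)phenyl, on the aromatic carbon between two ring nitrogen atoms, gives a number 56 percentage points lower from compound 3 to compound 4 (beyond the scatter), so in this set the dimethylsulfamoyl group alone does not hold the number up; it does so only as 4-(dimethylsulfamoyl)phenyl. Exchanging methoxycarbonyl for dimethylsulfamoyl on the phenyl ring gives only a number 10 percentage points lower from compound 2 to compound 4 (within the scatter), so this exchange does not separate the two compounds, and the large rise seen earlier goes with the 4-(dimethylsulfamoyl)phenyl arrangement rather than with the group's identity. The value of compound 1 is a limit of the assay, not a number, so a reading of a number at least 4 percentage points higher from compound 1 to compound 4 (that floor lies within the scatter) sets no order: the limit of < 5% in this assay, at which 1 of the 4 values shown sits.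

The compounds shown do not tell whether 4-(methoxycarbonyl)phenyl would rise as 4-(dimethylsulfamoyl)phenyl does, or whether the gain belongs to the dimethylsulfamoyl group in that arrangement only. They also leave open how a carboxylic acid or an amine on the phenyl ring would read, and they give no cause for the gap.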